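Fluoro in Place of Bromo: From Compound 1 to Compound 4

This account rests on a few compounds, and the source may have more. Where it says the series, first, only, none or still open, it means among the compounds named here.

Three compounds sharing one core were measured in a functional assay on HeLa cells (Homo sapiens) for inhibition, read by MTT assay, with a stated time of 24 h; a higher number here means a weaker inhibitor, a lower number a stronger inhibitor. Compound 1 `CCOC(=O)C1=Cc2ccccc2OC1(OCc1cc(-c2ccc(Br)cc2)no1)C(F)(F)F` gives 52300 nM in this assay. Compound 2 `CCOC(=O)C1=Cc2ccccc2OC1(OCc1cn(CC(=O)Nc2ccc(OC)cc2)nn1)C(F)(F)F` gives 31900 nM. Compound 3 `CCOC(=O)C1=Cc2ccccc2OC1(OCc1cn(-c2ccc([N+](=O)[O-])cc2)nn1)C(F)(F)F` reaches only the limit of > 150000 nM, a boundary of this assay rather than a number. Among the two numbers, compound 1 stands highest, with compound 2 nearest and within the scatter of it, so no order between these two can be claimed. Within the data shown here, the one measured step, an at least 4.7-fold higher number from compound 2 to compound 3 (0.67 log units; beyond the scatter), concerns a substituent on an aromatic nitrogen and rests on the limit (the limit of > 150000 nM in this assay, at which 1 of the 3 values shown sits).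

Compound 4 `CCOC(=O)C1=Cc2ccccc2OC1(OCc1cc(-c2ccc(F)cc2)no1)C(F)(F)F` is yet unmeasured and differs from compound 1 as follows:
fluoro in place of bromo on an aromatic carbon
Among the measured compounds shown here, no measured step touches the same place: the step from compound 2 to compound 3 alters a group on an aromatic nitrogen, not the halogen on the six-membered aromatic ring. For the swap of a bromine for a fluorine on that ring, the shown data therefore give no basis for expecting a change beyond the scatter in either direction. Compound 4 is estimated at 55000 nM in this assay, with a range from 25000 nM to 130000 nM. That estimate means an expected 1.1-fold higher number from compound 1 to compound 4 (0.02 log units; within the scatter).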

Compound 4, half-maximal inhibitory concentration: 42300 nM
Compound 4: middle estimate off by 1.3-fold (0.11 log units), on the high side; measured number inside the range.
By their numbers in this assay, from the lowest: compounds 2, 4 and 1 (each within the scatter of the next). At a limit, above all of these: compound 3.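

In this assay the 4-bromophenyl gives way to a 4-fluorophenyl, and the outcome is a 1.2-fold lower number from compound 1 to compound 4 (0.09 log units; within the scatter), so on this evidence the two halogens cannot be told apart at this place, on an aromatic carbon para to a large group. Among these compounds, the earlier compounds could not show this: their one measured step concerned a group on an aromatic nitrogen, and the six-membered aromatic ring bearing the halogen stayed untouched, whereas this pair gives the first reading of a change at that carbon, and it is a reading of no separable difference rather than of a gain or a loss. Nothing in the data shown bears on why the exchange stays within the scatter.

What remains open is whether a group of another kind at the same place, such as an amine, a carboxylic acid or a longer chain, would move the number beyond the scatter, since bromo and fluoro are the only groups shown there. On these data alone, it also remains open whether the same exchange would read the same way on another core or in any other assay.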